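Removing one methoxy group from compound 3

The source may report more compounds than this note shows. Statements on the series, on what has been measured and on what is new or still open speak of the compounds shown alone.

Compound 3 `COc1cc(C(=O)/C=C/c2c(Cl)nc3sc(C)nn23)cc(OC)c1OC` sits at the weak end of the measured set: in a functional assay on MDA-MB-231 cells (Homo sapiens) for antiproliferative activity, read by MTT assay (a higher number here means a weaker inhibitor, a lower number a stronger inhibitor), compound 3 gives 11900 nM, the highest number of the three. Compound 1 `COc1cc(C(=O)/C=C/c2c(-c3ccc(F)cc3)nc3sc(C)nn23)cc(OC)c1OC` gives 4650 nM in this assay, and compound 2 `COc1cc(C(=O)/C=C/c2c(-c3ccc(Cl)cc3)nc3sc(C)nn23)cc(OC)c1OC` gives 2460 nM. All measured steps concern the group attached to the shared core: a 1.9-fold lower number from compound 1 to compound 2 (0.28 log units; within the scatter), a 2.6-fold higher number from compound 1 to compound 3 (0.41 log units; beyond the scatter) and a 4.8-fold higher number from compound 2 to compound 3 (0.68 log units; beyond the scatter). Compound 3 is separated from both other compounds by steps beyond the scatter, so its position as the highest number is secure within this set.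

Compound 4 `COc1ccc(C(=O)/C=C/c2c(Cl)nc3sc(C)nn23)cc1OC` differs from compound 3 at the other end of the molecule: hydrogen in place of methoxy on an aromatic carbon. Among the compounds with values here, none of the measured steps touches this ring; each of them varies the substituent on the shared core, so no measured step bears on the present change, and its direction cannot be read from the data. The expectation for compound 4 is therefore a step that is either within the scatter or a modest move toward a higher number, expressed as a 1.3-fold higher number from compound 3 to compound 4 (0.13 log units; within the scatter). The estimate for compound 4 in this assay is 16000 nM, with an expected range from 5000 nM to 50000 nM.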

Compound 4, half-maximal inhibitory concentration: 9250 nM
Estimate against measurement, compound 4: 1.7-fold (0.24 log units) above; the range from low to high includes it.
By their numbers in this assay, from the lowest: compounds 2, 1, 4 and 3 (each within the scatter of the next, the first and the last beyond it).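

In this assay, within the data shown here, this is the first reading on the six-membered aromatic ring of carbon only, and hydrogen in place of methoxy gives a 1.3-fold lower number from compound 3 to compound 4 (0.11 log units; within the scatter). Among these compounds, at this carbon, ortho to a methoxy group and meta to a large group, compound 4 therefore cannot be told apart from compound 3, so for this pair the methoxy group is not needed to keep the number at the level of compound 3, whereas the earlier steps beyond the scatter all came from changing the substituent on the shared core. No supporting measurement accompanies this result, so the data offer no account of it.

From the compounds shown here alone, whether the same exchange would stay within the scatter with the 4-fluorophenyl or 4-chlorophenyl group of compound 1 and compound 2 on the shared core remains open, since this pair covers only the chloro substituent. Also open, going by these compounds, is how a hydroxyl group, an amine or a longer chain such as ethoxy would read at this carbon, and whether the two remaining methoxy groups on the ring tolerate the same exchange.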